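A few compounds are considered here, and "the series" means these few. Any claim that something is new, unique, unknown or untested is made for them only; others in the source may bear on it.

Measured compounds:
compound 1, `CCN1CCN(c2cc(C)c3cc(NC(=O)c4cccc(C)c4)ccc3n2)CC1`, 13700 nM
compound 2, `Cc1cc(N2CCCC2)nc2ccc(NC(=O)c3ccc(Cl)c(Cl)c3)cc12`, 43400 nM

Both compounds were tested in a functional assay on SK-BR-3 cells (Homo sapiens) for antiproliferative activity, read by MTT assay, with a stated time of 72 h; a lower number here means a stronger inhibitor, a higher number a weaker inhibitor. Compound 1 gives the lower of the two numbers, and compound 2 sits a good deal higher, a gap that lies beyond the usual scatter of this assay. The two compounds differ in more than one place, so nothing can be said about which change carries that gap.

The step followed here leads from compound 1 to compound 3, `CCN1CCN(c2cc(C)c3cc(NC(=O)c4ccccc4Cl)ccc3n2)CC1`, which has not yet been measured in this assay. The change is a single one on the amide side of the molecule: 2-chlorophenyl in place of 3-methylphenyl on a carbonyl carbon. The group that leaves and the group that enters are alike in size, and neither adds a hydrogen-bond donor or acceptor. For the measured compounds named here, no measured pair in this set shows a comparable change, so there is no measured step to lean on. Compound 3 is therefore expected to land close to compound 1, with the step of a 1.5-fold higher number from compound 1 to compound 3 (0.16 log units; within the scatter) estimated to be small, within the scatter or slightly weakening. The estimate for compound 3 in this assay is 20000 nM, in a range from 6000 nM to 65000 nM.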

Compound 3, half-maximal inhibitory concentration: > 50000 nM
Compound 3 was reported as a limit; the forecaster's own chance of this, stated with the estimate: 10%; middle value at least 2.5-fold (0.39 log units) away from the limit.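

In this assay, for the compounds shown here, this is the first change in the set made at one place only, and it shows that the group on the amide carbonyl matters to the read-out: an at least 3.6-fold higher number from compound 1 to compound 3 (0.56 log units; beyond the scatter). The earlier pair of compounds could not show this, since compound 1 and compound 2 differ in more than one place. The change also separates two groups that match in every count computed here, with 7 heavy atoms, one six-membered aromatic ring of carbon only, and no hydrogen-bond donors or acceptors, so those counts alone do not settle the outcome, and compound 3 is reported only as a limit, which makes the step a minimum and not a measured size: the limit of > 50000 nM in this assay, at which 1 of the 3 values shown sits.

The names 3-methylphenyl and 2-chlorophenyl differ both in the group carried on the ring and in the number that places it, and the compounds shown cannot tell which of the two carries the step. Also open, going by these compounds, is where a plain phenyl or an aminophenyl on the same carbonyl carbon would fall in this assay, and whether any group there gives a lower number than compound 1 does.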